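Swapping a difluorophenyl for a thiazolyl pyrrolidinone

The source may hold more compounds than are shown below. What is called first, only, known or untested is meant among the compounds shown, and "the series" means these compounds.

Within the data shown here, compound 1 `O=C(Nc1cc(F)c(F)c(F)c1)N1Cc2c(-c3ccc(F)cc3F)cnn2CC1C1CC1` is the only compound here with a numeric reading: in a toxicity assay on HepG2 2.2.15 cells (Homo sapiens) for cytotoxicity, read by CellTiter-Glo (on this read-out higher numbers stand for lower toxicity in this test and lower numbers for higher toxicity in this test), compound 1 gives 32100 nM. Compound 2 `C[C@H]1Cn2ncc(N3CC(c4ccccc4)CC3=O)c2CN1C(=S)Nc1cc(F)c(F)c(F)c1` is reported in this assay only as a limit, > 2000 nM, not as a number. Compound 3 `O=C1CC(c2nccs2)CN1c1cnn2c1CN(C(=O)Nc1cc(F)c(F)c(F)c1)C(C1CC1)C2` differs from compound 1 in one place: 2-oxo-4-(1,3-thiazol-2-yl)pyrrolidin-1-yl in place of 2,4-difluorophenyl on an aromatic carbon. Among the measured compounds shown here, no measured step between compounds connects this change, so the expected size is uncertain, and no shift beyond the usual scatter is expected from compound 1 to compound 3, a 1.1-fold lower number from compound 1 to compound 3 (0.03 log units; within the scatter). Compound 3 is therefore estimated at 30000 nM, within 10000 nM to 90000 nM.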

Compound 3, half-maximal cytotoxic concentration: 115000 nM
For compound 3 the middle estimate is 3.8-fold (0.58 log units) below the measured one; measured number above the stated range.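

At this aromatic carbon, 2-oxo-4-(1,3-thiazol-2-yl)pyrrolidin-1-yl in place of 2,4-difluorophenyl gives a 3.6-fold higher number from compound 1 to compound 3 (0.55 log units; beyond the scatter) in this assay, so the group held here does influence this read-out, and this change moves it toward lower toxicity in this test. No measurement shown accounts for the shift. Among these compounds, the single step cannot separate the contribution of the pyrrolidinone from that of the thiazole. As far as these compounds go, how a small amine or a carboxylic acid at this carbon would read remains open.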